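The source may report more compounds than this note shows. Statements on the series, on what has been measured and on what is new or still open speak of the compounds shown alone.

Of the compounds shown here, three sharing a core have numbers so far in a functional assay on MCF7 cells (Homo sapiens) for cytotoxicity, read by MTT assay, with a stated time of 96 h (on this read-out lower numbers stand for stronger inhibition and higher numbers for weaker inhibition), on the same scale. Compound 1 `COc1cc(C(=O)c2cn(-c3ccccc3)cc2-c2ccc(N)cc2)cc(OC)c1OC` comes in at 9 nM and compound 2 `COc1ccc(-n2cc(C(=O)c3cc(OC)c(OC)c(OC)c3)c(-c3ccccc3)c2)cc1` at 120 nM while compound 3 `COc1cc(C(=O)c2cn(-c3ccccc3)cc2-c2ccccc2C)cc(OC)c1OC` stands at 190 nM in these measurements. The number for compound 3 lies within the usual scatter of the number for compound 2, so those two cannot be ranked. The gap to compound 1 is real: the measured step with 2-methylphenyl in place of 4-aminophenyl gives a 21-fold higher number from compound 1 to compound 3 (1.32 log units; beyond the scatter) and counts as large.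

Compound 4 `COc1cc(C(=O)c2cn(-c3ccccc3)cc2-c2ccccc2Cl)cc(OC)c1OC` is still unmeasured. It carries chloro in place of methyl on an aromatic carbon and otherwise matches compound 3. Within the data shown here, the one measured step exchanged a different pair of groups. 4-aminophenyl is absent from compound 3 and compound 4 alike, so the low number of compound 1 at 9 nM offers little guidance here, and no measured step swaps methyl for chloro. No step beyond the scatter is therefore expected in this assay in either direction. The expected change is a 1.2-fold lower number from compound 3 to compound 4 (0.07 log units; within the scatter) and remains a rough estimate. The value estimated for compound 4 is 160 nM with an expected range from 70 nM to 400 nM when it is measured.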

Compound 4, half-maximal inhibitory concentration: 76 nM
Compound 4: middle estimate off by 2.1-fold (0.32 log units), on the high side, within the range that was stated.
By their numbers in this assay, from the lowest: compound 1; then compounds 4, 2 and 3 (each within the scatter of the next, the first and the last beyond it).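

Methyl and chloro each count as a single heavy atom, and neither adds a hydrogen-bond donor or acceptor, yet this small exchange on an aromatic carbon, ortho to a large group, gives a real change in this assay (a 2.5-fold lower number from compound 3 to compound 4 (0.40 log units; beyond the scatter)). So this position responds to a change of one atom, which the earlier compounds could not show, as their only measured step replaced the whole 4-aminophenyl group with 2-methylphenyl. The 2-chlorophenyl group still falls short of 4-aminophenyl (an 8.4-fold higher number from compound 1 to compound 4 (0.93 log units; beyond the scatter)), and no measurement at hand explains why chloro gives a lower number than methyl here.

The compounds shown leave open whether this effect is special to chloro or would also appear with fluoro, bromo or trifluoromethyl on the same carbon. They also leave open whether chloro and the amine of compound 1 would lower the number further if they were carried together on one ring.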